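Methoxy for Fluoro on the Outer Aromatic Ring

A few compounds are considered here, and "the series" means these few. Any claim that something is new, unique, unknown or untested is made for them only; others in the source may bear on it.

Compound 3 `COc1ccc(F)cc1CNCCCNc1ccnc2cc(-c3ccc(F)cc3)ccc12` gives 9.47 in a physicochemical assay for acid dissociation. Compound 2 `COc1ccc(F)cc1CNCCCNc1ccnc2cc(Cc3cc(C)cc(C)c3)ccc12` gives 9.47, level with compound 3 at the digits shown. Compound 1 `COc1ccc(Oc2ccc3c(NCCCNCc4cc(F)ccc4OC)ccnc3c2)cc1` gives 9.28, and the step of a number 0.19 log units higher from compound 1 to compound 3 (within the scatter) stays within the scatter. Compound 4 `COc1ccc(-c2ccc3c(NCCCNCc4cc(F)ccc4OC)ccnc3c2)cc1` differs from compound 3 by methoxy in place of fluoro on an aromatic carbon. The changes already measured at that same aromatic carbon are the steps of a number 0.19 log units higher from compound 1 to compound 2 (within the scatter) and no change at the digits printed from compound 2 to compound 3 (within the scatter), neither beyond the scatter. For the step of a number 0.02 log units lower from compound 3 to compound 4 (within the scatter) no movement beyond the scatter is expected, given that no change at the digits printed from compound 2 to compound 3 (within the scatter) and a number 0.19 log units higher from compound 1 to compound 3 (within the scatter) were both within it. For compound 4 the estimate is 9.45, with a range from 9.15 to 9.75.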

Compound 4, acid dissociation constant: 9.47
For compound 4 the middle estimate is 0.02 log units below the measured one; measured number inside the range.
By their numbers in this assay, from the lowest: compounds 1, 2, 3 and 4 (each within the scatter of the next).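

In this assay, among these compounds, the exchange of fluoro for methoxy gives no change at the digits printed from compound 3 to compound 4 (within the scatter), the first reading of a change on the outer ring itself, para to a large group, rather than of the whole group on the shared core. The 4-methoxyphenyl group also shows no change at the digits printed from compound 2 to compound 4 (within the scatter) against 3,5-dimethylbenzyl and a number 0.19 log units higher from compound 1 to compound 4 (within the scatter) against 4-methoxyphenoxy, so all four groups at this aromatic carbon lie within the scatter of one another. Nothing available gives a reason for this result. The compounds shown leave open whether an amine or a carboxylic acid on that outer ring would move the number beyond the scatter.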